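Neopentylamino at the core position in compound 4

A few compounds are considered here, and "the series" means these few. Any claim that something is new, unique, unknown or untested is made for them only; others in the source may bear on it.

Measured so far:
compound 1 `Cc1nc(NCc2ccc(Cl)cc2)cc(-c2ccccn2)n1` with 81 nM
compound 2 `CNc1nc(NCc2ccc(S(C)(=O)=O)cc2)cc(-c2ccccn2)n1` with 36 nM
compound 3 `c1ccc(-c2cc(NCC3CC3)ncn2)nc1` with 22000 nM

In a functional assay on HEK293 cells for agonist activity at G-protein coupled receptor 39 (Homo sapiens), read by inositol phosphate accumulation (on this read-out higher numbers stand for an effect only at larger amounts of compound and lower numbers for an effect already at smaller amounts), compound 3 stands with the highest of the three numbers, and the gap to compound 1 as well as to compound 2 lies beyond the scatter. Within the data shown here, compound 1 and compound 2 both carry a group on the aromatic carbon between the two ring nitrogen atoms, whereas compound 3 has hydrogen there; the values of the two pairs also differ in the amine on the other side of the core, so no single-change step is available, and the comparison is left as it stands.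

Compound 4 `CC(C)(C)CNc1nc(NCC2CC2)cc(-c2ccccn2)n1` is the next step: neopentylamino in place of hydrogen on an aromatic carbon. A move to a lower number is expected, with a step in this assay of a 15-fold lower number from compound 3 to compound 4 (1.17 log units; beyond the scatter), since the substituted compound 1 gives 81 nM and compound 3 gives 22000 nM. For compound 4 an estimated value of 1500 nM is expected, in the range 300 nM to 8000 nM.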

Compound 4, half-maximal effective concentration: 5000 nM
The estimate for compound 4 lay 3.3-fold (0.52 log units) below the measured number, and the stated range covers the measured number.
By their numbers in this assay, from the lowest: compound 2; then compound 1; then compound 4; then compound 3.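

In this assay, this position gives its first single-change reading: neopentylamino in place of hydrogen on the aromatic carbon between two ring nitrogen atoms gives a 4.4-fold lower number from compound 3 to compound 4 (0.64 log units; beyond the scatter). The step is modest but beyond the scatter, so with the (cyclopropylmethyl)amino group held fixed, this position accepts the branched chain and the number moves down rather than up. Nothing available accounts for the size of this step.

As far as these compounds go, it remains open whether a primary amino group, a hydroxyl group or a longer straight alkylamino chain at this position would give a larger or smaller step. From the compounds shown here alone, it is also open whether neopentylamino would give a similar step with the chlorobenzyl amine of compound 1 in place of the (cyclopropylmethyl)amino group.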